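One group replaced on compound 3

The source may report more compounds than this note shows. Statements on the series, on what has been measured and on what is new or still open speak of the compounds shown alone.

Three related compounds have numbers in a functional assay on HCT-116 cells (Homo sapiens) for inhibition, read by colorimetric assay, with a stated time of 3 days; a higher number here means a weaker inhibitor, a lower number a stronger inhibitor. Compound 1 `O=C(CCCCCCNC(=O)C(O)(O)C(F)(F)F)Nc1nc2ccccc2o1` gives 3450 nM, a clearly stronger result than that of compound 3. Compound 2 `COc1cc(NC(=O)CCCCCCNC(=O)C(O)(O)C(F)(F)F)cc(OC)c1OC` gives 14100 nM. Compound 3 `O=C(CCCCNC(=O)C(O)(O)C(F)(F)F)Nc1ccccc1` gives 20300 nM, which lies within the usual scatter of the number for compound 2 and well above the number for compound 1.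

Compound 4 `C/C(=N\O)C(=O)NCCCCC(=O)Nc1ccccc1` alters compound 3 in one place: a group of 4 heavy atoms (2 carbon, 1 nitrogen, 1 oxygen; no ring) in place of a group of 7 heavy atoms (2 carbon, 2 oxygen, 3 fluorine; no ring), on a carbonyl carbon. Among the measured compounds shown here, no measured pair shows a change of this kind, so the forecast is loose, and no shift beyond the scatter is expected. The estimated change is a 1.5-fold higher number from compound 3 to compound 4 (0.17 log units; within the scatter). For compound 4 the estimate is 30000 nM, with an expected range of 9000 nM to 100000 nM.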

Compound 4, half-maximal inhibitory concentration: > 100000 nM
Compound 4: a limit, no number; the forecaster's own chance of this, stated with the estimate: 25%; middle value at least 3.3-fold (0.52 log units) from the limit.
By their numbers in this assay, from the lowest: compound 1; then compounds 2 and 3 (each within the scatter of the next). At a limit, above all of these: compound 4.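

In this assay, swapping the 2,2,2-trifluoro-1,1-dihydroxyethyl group on the carbonyl carbon for a group of fewer heavy atoms with a double bond gives an at least 4.9-fold higher number from compound 3 to compound 4 (0.69 log units; beyond the scatter). Among the compounds shown here, this is the only step here that changes one place alone, so it gives the first direct sign that the number depends on the group at this position. Compound 4 has only a limit, not a number, so the true step may be larger: the limit of > 100000 nM in this assay, at which 1 of the 4 values shown sits.

As far as these compounds go, it remains open whether another group here, such as a carboxylic acid or an amine, would give a measurable number. From the compounds shown here alone, it is also open whether the same swap would have a similar effect on the core of compound 1.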